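Methoxy on the pyridyl ring of the shared core

A few compounds are considered here, and "the series" means these few. Any claim that something is new, unique, unknown or untested is made for them only; others in the source may bear on it.

Measured so far:
compound 1 `C[C@@H](O[C@H]1CN2C(=O)C=C(c3ccccc3)CC2[C@@H]1c1ccc(F)cc1)c1cc(C(F)(F)F)cc(C(F)(F)F)c1` — 89.5 nM
compound 2 `C[C@@H](O[C@H]1CN2C(=O)C=C(c3ccc(CO)cc3)CC2[C@@H]1c1ccc(F)cc1)c1cc(C(F)(F)F)cc(C(F)(F)F)c1` — 23 nM
compound 3 `C[C@@H](O[C@H]1CN2C(=O)C=C(c3ccncc3)CC2[C@@H]1c1ccc(F)cc1)c1cc(C(F)(F)F)cc(C(F)(F)F)c1` — 8.1 nM

In an assay on CHO cells for displacement of a labelled ligand from Substance-P receptor (Homo sapiens), in the presence of a further agent that is not named here (on this read-out higher numbers stand for weaker inhibition and lower numbers for stronger inhibition), compound 3 holds the lowest number of the three; the steps of a 2.8-fold lower number from compound 2 to compound 3 (0.45 log units; beyond the scatter) and an 11-fold lower number from compound 1 to compound 3 (1.04 log units; beyond the scatter) both lie beyond the scatter, so compound 3 is the strongest inhibitor shown. Compound 4 `COc1cc(C2=CC(=O)N3C[C@H](O[C@H](C)c4cc(C(F)(F)F)cc(C(F)(F)F)c4)[C@@H](c4ccc(F)cc4)C3C2)ccn1` differs from compound 3 by methoxy in place of hydrogen on an aromatic carbon.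

Among the compounds with values here, the only measured step that adds a group onto the aryl ring attached to the double-bonded ring carbon is a 3.9-fold lower number from compound 1 to compound 2 (0.59 log units; beyond the scatter), a modest gain. Within the data shown here, no measured step adds a group onto the pyridyl ring itself, and no measured step places a group next to the ring nitrogen, so the bearing of that step on compound 4 is indirect. A small step is expected in this assay, a 1.4-fold lower number from compound 3 to compound 4 (0.13 log units; within the scatter), not far outside the scatter and more likely downward than upward. Compound 4 is therefore expected to give about 6 nM in this assay. The expected range for compound 4 runs from 2 nM to 18 nM.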

Compound 4, half-maximal inhibitory concentration: 44 nM
Beside the measured number, compound 4's estimate is 7.3-fold (0.87 log units) below it; the measured number lies above the stated range.
By their numbers in this assay, from the lowest: compound 3; then compounds 2 and 4 (each within the scatter of the next); then compound 1.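

In this assay, within the data shown here, methoxy next to the ring nitrogen gives the first measured step on the pyridyl ring itself, a 5.4-fold higher number from compound 3 to compound 4 (0.73 log units; beyond the scatter), and it runs opposite to the hydroxymethyl step on the phenyl ring, a 3.9-fold lower number from compound 1 to compound 2 (0.59 log units; beyond the scatter). Much of the gain from pyridin-4-yl is lost with this change, yet a 2.0-fold lower number from compound 1 to compound 4 (0.31 log units; beyond the scatter) keeps 2-methoxypyridin-4-yl ahead of phenyl, while a 1.9-fold higher number from compound 2 to compound 4 (0.28 log units; within the scatter) leaves compound 2 and compound 4 within the scatter of each other. Nothing in the data bears on why methoxy at this place weakens inhibition.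

From the compounds shown here alone, it remains open whether an amine or a methyl group at the same place, next to the ring nitrogen, would follow methoxy. Also open, going by these compounds, is whether hydroxymethyl on the pyridyl ring would repeat its step on the phenyl ring.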